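The compounds below may be only part of what the source reports. "The series", "measured", "known", "first", "only" and "open" are said of these compounds alone.

Measured in an assay on Sf21 cells for inhibition of ubiquitin carboxyl-terminal hydrolase 7 (Homo sapiens), read by spectrophotometry, with stated times of 30 min and 2 h; on this read-out lower numbers stand for stronger inhibition and higher numbers for weaker inhibition:

Compound 1, `O=c1c2cnn(-c3ccc(F)cc3)c2ncn1CC1(O)CCN(Cc2ccccc2Cl)CC1`: 3400 nM
Compound 2, `O=c1c2cnn(-c3ccc(F)cc3)c2ncn1CC1(O)CCN(Cc2ccccc2Br)CC1`: 3100 nM
Compound 3, `COC(=O)c1ccccc1CN1CCC(O)(Cn2cnc3c(cnn3-c3ccc(F)cc3)c2=O)CC1`: "not determined" (no result reported)

Compound 3 thus has no number of its own in this assay and stands outside the comparison that compounds 1 and 2 allow. Compound 4 is `O=c1c2cnn(-c3ccc(F)cc3)c2ncn1CC1(O)CCN(Cc2ccc(F)cc2Cl)CC1`. It differs from compound 3 by 2-chloro-4-fluorophenyl in place of 2-(methoxycarbonyl)phenyl on a saturated chain carbon bound to an amine nitrogen in a ring. Among the compounds with values here, no measured step covers this change directly. Within the data shown here, the only measured step, a 1.1-fold lower number from compound 1 to compound 2 (0.04 log units; within the scatter), exchanges one halogen for another on the benzyl group and sits within the scatter, so a small change to this halogenated benzyl group left the number roughly where it was. Compound 4 carries the same chloro-substituted benzyl group as compound 1 with one fluorine added, and since compound 1 gives 3400 nM while compound 2 gives 3100 nM, a value in the same region is expected for compound 4, with no step beyond the scatter in either direction. Compound 4 is therefore estimated at 3000 nM, with a likely range from 1000 nM to 9000 nM.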

Compound 4, half-maximal inhibitory concentration: 1600 nM
Estimate against measurement, compound 4: 1.9-fold (0.27 log units) above; low and high end bracket the measured number.
By their numbers in this assay, from the lowest: compounds 4, 2 and 1 (each within the scatter of the next, the first and the last beyond it).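

In this assay, within the data shown here, adding a fluoro group to the chloro-substituted benzyl group of compound 1, which makes the 2-chloro-4-fluorobenzyl group, is the first change here to go beyond the usual scatter, with a 2.1-fold lower number from compound 1 to compound 4 (0.33 log units; beyond the scatter), although the step is modest. Against the bromo compound the picture is less clear: a 1.9-fold lower number from compound 2 to compound 4 (0.29 log units; within the scatter) stays within the scatter, so these two compounds cannot be told apart. No supporting data are available to explain the effect of the added fluoro group.

The compounds shown leave open whether a different group in place of that fluoro, such as methoxy or a nitrile, would give a similar number. They also leave open how a benzyl group carrying the fluoro without the chloro would compare, and compound 3 gives no number that places the 2-(methoxycarbonyl)benzyl group.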